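A few compounds are considered here, and "the series" means these few. Any claim that something is new, unique, unknown or untested is made for them only; others in the source may bear on it.

Compound 1 `CCNC(=O)c1noc(-c2cc(C(C)C)c(O)cc2O)c1-c1cc(COCC(=O)O)no1`: "not determined" (no result reported)
Compound 2 `CCNC(=O)c1noc(-c2cc(C(C)C)c(O)cc2O)c1-c1cc(CNC(C)=O)no1`: 167 nM

Among the measured compounds shown here, in a functional assay on HCT-116 cells (Homo sapiens) for inhibition (a lower number here means a stronger inhibitor, a higher number a weaker inhibitor), compound 2 holds the only number, 167 nM, because compound 1 has no reported result, so its standing cannot be ranked. Compound 3 `CCNC(=O)c1noc(-c2cc(C(C)C)c(O)cc2O)c1-c1cc(CNC(=O)CC)no1` extends acetamido to propanoylamino: methyl in place of hydrogen on a saturated chain carbon bound to a carbonyl carbon, with methyl in place of hydrogen on a saturated chain carbon bound to a carbonyl carbon. For the measured compounds named here, no measured step shows what this change does. In this assay, a change no larger than the usual scatter is expected, with no firm direction. The expected step is a 1.1-fold higher number from compound 2 to compound 3 (0.03 log units; within the scatter). For compound 3 the estimated value is 180 nM, with an expected range of 80 nM to 400 nM.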

Compound 3, half-maximal inhibitory concentration: 78 nM
Compound 3: the middle estimate sits 2.3-fold (0.36 log units) above what was measured; measured number outside the range, below it.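

In this assay extending acetamido to propanoylamino gives a 2.1-fold lower number from compound 2 to compound 3 (0.33 log units; beyond the scatter) and so shows that this place on the chain is not indifferent to a single added methyl. The step is modest yet beyond the scatter, and the entering methyl adds no hydrogen-bond donors or acceptors. Nothing at hand explains the step. As far as these compounds go, whether a longer chain such as butanoyl would go further in the same direction remains open, since one step sets no trend. From the compounds shown here alone, the effect of an amine or a carboxylic acid at the end of this chain also remains open.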